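Ring-isomer swap on the amide nitrogen of the furan series

The source may report more compounds than this note shows. Statements on the series, on what has been measured and on what is new or still open speak of the compounds shown alone.

Notes on the series. Compound 1 `Cc1cc(-c2ccc(C(=O)N(C)c3ccccc3C)o2)ccc1OS(N)(=O)=O` has in an assay on T47D cells for inhibition of Steryl-sulfatase (Homo sapiens), read by HPLC, with a stated time of 24 h (a higher number here means a weaker inhibitor, a lower number a stronger inhibitor), no reported result, compound 1 standing at "nd" (no result reported). Among the measured compounds shown here, compound 2 `Cc1ccccc1N(C)C(=O)c1ccc(-c2ccc(OS(N)(=O)=O)cc2F)o1` gives in this assay a value of 16 nM, the only number so far in this set. For the measured compounds named here, compound 3 `Cc1cccc(F)c1N(C)C(=O)c1ccc(-c2ccc(OS(N)(=O)=O)cc2)o1` likewise has no number in this assay, compound 3 standing at "nd" (no result reported); it is one of two entries without a single number, so no step can be drawn from it. Compound 4 `Cc1c(F)cccc1N(C)C(=O)c1ccc(-c2ccc(OS(N)(=O)=O)cc2)o1` is the next structure to be measured. It differs from compound 3 only in the arrangement of the same atoms: 3-fluoro-2-methylphenyl in place of 2-fluoro-6-methylphenyl on an amide-type nitrogen, so the change is small and confined to one aromatic substituent. Going by the values given here, with no measured step from compound 3 available, no direction can be drawn from the data; the expectation is a result near the one number the series shows, within the scatter of repeated measurements. In this assay compound 4 is estimated at 20 nM, with a range from 5 nM to 80 nM.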

Compound 4, half-maximal inhibitory concentration: 25 nM
Estimate against measurement, compound 4: 1.3-fold (0.10 log units) below; measured number inside the range.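

Compound 3 stands without a single number, so no new step can be read from compound 3 to compound 4. In this assay the compounds shown leave open how 3-fluoro-2-methylphenyl and 2-fluoro-6-methylphenyl compare on the amide-type nitrogen. Nothing available explains the result of compound 4.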